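The compounds below may be only part of what the source reports. "The series", "measured", "known", "first", "only" and "open" are said of these compounds alone.

In a functional assay on HCT-116 cells (Homo sapiens) for antiproliferative activity, read by MTT assay, with a stated time of 48 h (on this read-out higher numbers stand for weaker inhibition and lower numbers for stronger inhibition), compound 1 (`CCCCCCCC[C@@H](CCO)n1cnc2c(Cl)ncnc21`) gives 3400 nM while compound 2 (`CCCCCCCC[C@H](CCO)n1cnc2c(Cl)ncnc21`) gives 1120 nM and so holds the lower of the two numbers. Compound 3 (`CCCCCCCCC(CCO)n1cnc2c(Cl)ncnc21`) has the same atoms and bonds as compound 2, but its stereocentre at a saturated chain carbon is drawn without a configuration (the two compounds have the same atoms and bonds; at least one stereo element is drawn with a configuration in one of them and without one in the other: 1 of 1 stereo elements differ; a stereocentre at a saturated chain carbon is drawn R in compound 2 and without a configuration in compound 3). Among the compounds with values here, the one measured step that bears on this (a 3.0-fold lower number from compound 1 to compound 2 (0.48 log units; beyond the scatter)) is modest, and the fact that compounds 1 and 2 differ only in the configuration as drawn is all that separates that pair, so compound 3 is expected to fall between the two values. The expected change is small and towards a higher number (a 1.6-fold higher number from compound 2 to compound 3 (0.21 log units; within the scatter)). The estimate for compound 3 is 1800 nM (range 1000 nM to 3400 nM).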

Compound 3, half-maximal inhibitory concentration: 1650 nM
For compound 3 the middle estimate is 1.1-fold (0.04 log units) above the measured one, within the range that was stated.
By their numbers in this assay, from the lowest: compounds 2 and 3 (each within the scatter of the next); then compound 1.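

In this assay, a stereocentre drawn without a configuration at this saturated chain carbon cannot be told apart from the R form, with a 1.5-fold higher number from compound 2 to compound 3 (0.17 log units; within the scatter). Set against the S form, the same change is modest but does exceed the scatter, with a 2.1-fold lower number from compound 1 to compound 3 (0.31 log units; beyond the scatter). Only one thing separates that last pair: the fact that one of compounds 1 and 3 is drawn with a defined configuration and the other without, at the place where they differ

The compounds shown leave open whether the configuration at this carbon would still matter with an amine in place of the hydroxyl group, or with a longer chain.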